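Replacing the Carboxy Group on the Shared Core

This account rests on a few compounds, and the source may have more. Where it says the series, first, only, none or still open, it means among the compounds named here.

Compound 1 `O=S1(=O)Cc2nc(-c3cc(F)c(Cl)cc3F)nc(N3CCC(CO)CC3)c2C1` gives 3.9 nM in a functional assay on HEK293 cells for agonist activity at Glucose-dependent insulinotropic receptor (Homo sapiens), read by reporter gene assay and cAMP accumulation, with a stated time of 6 h; on this read-out higher numbers stand for an effect only at larger amounts of compound and lower numbers for an effect already at smaller amounts.
Compound 2 `O=C(O)C1CCN(c2nc(-c3cc(F)c(Cl)cc3F)nc3c2CS(=O)(=O)C3)CC1` gives 560 nM in this assay.

For the measured compounds named here, compound 2 stands highest of these two numbers; its only neighbour is compound 1, and the step between them is a 140-fold higher number from compound 1 to compound 2 (2.16 log units; beyond the scatter). Compound 3 `NC(=O)CN1CCN(c2nc(-c3cc(F)c(Cl)cc3F)nc3c2CS(=O)(=O)C3)CC1` differs from compound 2 in one place: 4-(carbamoylmethyl)piperazin-1-yl in place of 4-carboxypiperidin-1-yl on an aromatic carbon. Going by the values given here, the one measured step bears on this change, since it was the carboxy group entering that went with the large rise, and compound 3 no longer carries that group. A large fall in this assay is therefore expected, a 19-fold lower number from compound 2 to compound 3 (1.27 log units; beyond the scatter). Compound 3 is estimated at 30 nM, with a range from 5 nM to 200 nM.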

Compound 3, effective concentration (reported as EC, without a stated level of effect): 44 nM
Beside the measured number, compound 3's estimate is 1.5-fold (0.17 log units) below it; measured number inside the range.
By their numbers in this assay, from the lowest: compound 1; then compound 3; then compound 2.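

At this position, on an aromatic carbon of the shared core, 4-(carbamoylmethyl)piperazin-1-yl regains much of the ground lost with 4-carboxypiperidin-1-yl in this assay, with a 13-fold lower number from compound 2 to compound 3 (1.10 log units; beyond the scatter). The regain is only partial, since 4-(hydroxymethyl)piperidin-1-yl remains better placed, with an 11-fold higher number from compound 1 to compound 3 (1.05 log units; beyond the scatter). No measurement on these compounds offers a reason for either step. The ring and the side chain change together, and the compounds shown do not separate their shares. A piperidine carrying the carbamoylmethyl chain, or a piperazine carrying a carboxylic acid, would divide them.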